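The source may hold more compounds than are shown below. What is called first, only, known or untested is meant among the compounds shown, and "the series" means these compounds.

Three compounds that differ only in the group on an aromatic carbon of the shared core were tested in a functional assay on K562 cells (Homo sapiens), read by MTT assay, with a stated time of 72 h; a lower number here means a stronger inhibitor, a higher number a weaker inhibitor. Compound 1 `Nc1nc2c(c(-c3ccco3)cn2[C@@H]2O[C@H](CO)[C@@H](O)[C@H]2O)c(=O)[nH]1`, carrying furan-2-yl, gives > 20000 nM, which is a limit and not a number. Compound 2 `Nc1nc2c(c(-c3ccoc3)cn2[C@@H]2O[C@H](CO)[C@@H](O)[C@H]2O)c(=O)[nH]1`, carrying furan-3-yl, gives 19600 nM. Compound 3 `Nc1nc2c(c(-c3ccsc3)cn2[C@@H]2O[C@H](CO)[C@@H](O)[C@H]2O)c(=O)[nH]1`, carrying thiophen-3-yl, gives > 20000 nM, again a limit and not a number. It therefore stands at the limit of > 20000 nM in this assay, at which 2 of the 3 values shown sit. The measured steps say little: an at least 1.0-fold lower number from compound 1 to compound 2 (0.00 log units; that floor lies within the scatter) and an at least 1.0-fold higher number from compound 2 to compound 3 (0.00 log units; that floor lies within the scatter) are only floors within the scatter, and a step that the two limits leave unreadable from compound 1 to compound 3 cannot be sized. Compound 4 `Nc1nc2c(c(-c3cc4ccccc4o3)cn2[C@@H]2O[C@H](CO)[C@@H](O)[C@H]2O)c(=O)[nH]1` brings a larger change: 1-benzofuran-2-yl in place of thiophen-3-yl on an aromatic carbon. Going by the values given here, none of the measured steps adds a ring, so they bear on this change only weakly. In this assay a modestly lower number is expected, though a step beyond the scatter is not assured. The expected step is an at least 1.3-fold lower number from compound 3 to compound 4 (0.12 log units; that floor lies within the scatter). For compound 4 the estimated value is 15000 nM, with an expected range of 5000 nM to 40000 nM.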

Compound 4, half-maximal inhibitory concentration: > 20000 nM
Compound 4: a limit, no number; the forecaster's own chance of this, stated with the estimate: 55%; middle value at least 1.3-fold (0.12 log units) away from the limit.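

In this assay compound 4 gives > 20000 nM, which is a limit and not a number. Going by these compounds alone, the one step with a floor is an at least 1.0-fold higher number from compound 2 to compound 4 (0.00 log units; that floor lies within the scatter), which lies within the scatter, and the steps to compound 4 from compound 1 and from compound 3 cannot be read. So on this aromatic carbon, the group of 9 heavy atoms with its added six-membered aromatic ring of carbon only does not bring a readable number, and the series stays at the top of the range tested: the limit of > 20000 nM in this assay, at which 3 of the 4 values shown sit.

Going by these compounds, how far compound 1, compound 3 and compound 4 actually lie beyond their limits stays open. So does whether a non-aromatic group on this carbon, such as an amine or a longer alkyl chain, would give a clearly lower number.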